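Swapping trifluoromethyl for chloro on an aromatic carbon

This account rests on a few compounds, and the source may have more. Where it says the series, first, only, none or still open, it means among the compounds named here.

Of the compounds shown here, two have been measured so far in an ADME assay on Vero cells (Chlorocebus sabaeus) for cytotoxicity, read by resazurin assay, with a stated time of 72 h (a lower number here means a stronger inhibitor, a higher number a weaker inhibitor), and they read as follows.
Compound 1 `Cc1ccc(C(=O)CCN2CCN(c3ccc(Cl)cc3)CC2)cc1` gives 184000 nM
Compound 2 `O=C(CCN1CCN(c2ccc(C(F)(F)F)cc2)CC1)c1ccc(C(F)(F)F)cc1` gives 49200 nM

Compound 2 holds the lower of these two numbers, and the gap to compound 1 is larger than the usual scatter of repeated measurements. The next molecule, compound 3 `O=C(CCN1CCN(c2ccc(Cl)cc2)CC1)c1ccc(C(F)(F)F)cc1`, has not been measured yet. It differs from compound 2 in a single place, counted as chloro in place of trifluoromethyl on an aromatic carbon and best read as chloro in place of trifluoromethyl on an aromatic carbon, so that a 4-(trifluoromethyl)phenyl becomes a 4-chlorophenyl. For the measured compounds named here, no measured pair shows this swap on its own, so the size of its effect in this assay has no direct precedent here. Going by the values given here, the only other reference is compound 1 at 184000 nM and it suggests a modest move upward, towards a weaker number. The expected 1.5-fold higher number from compound 2 to compound 3 (0.18 log units; within the scatter) is small and may stay within the scatter. For compound 3 the estimated value is 75000 nM with an expected range from 32000 nM to 170000 nM in this measurement.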

Compound 3, half-maximal inhibitory concentration: 54200 nM
Beside the measured number, compound 3's estimate is 1.4-fold (0.14 log units) above it, and the stated range covers the measured number.
By their numbers in this assay, from the lowest: compounds 2 and 3 (each within the scatter of the next); then compound 1.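

In this assay, chloro in place of trifluoromethyl on an aromatic carbon gives a 1.1-fold higher number from compound 2 to compound 3 (0.04 log units; within the scatter), so this assay does not separate the two groups at this position, although one heavy atom stands in place of four. A change at a different place in the molecule, trifluoromethyl in place of methyl on an aromatic carbon, gives a 3.4-fold lower number from compound 1 to compound 3 (0.53 log units; beyond the scatter), a step that does lie beyond the scatter. Across these two single changes, then, the number moves with the swap from methyl to trifluoromethyl and not with the swap from trifluoromethyl to chloro. Nothing measured alongside these numbers bears on the reason for either step.

As far as these compounds go, it remains open whether other groups at the 4-chlorophenyl position, such as a nitrile, a methoxy group or an amine, would also stay within the scatter of compound 2 and compound 3. The three compounds also cannot show whether chloro and trifluoromethyl would remain equivalent there if the other aromatic ring carried methyl instead of trifluoromethyl.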